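Fluorine on the pendant phenyl: a paired replacement in two cores

A few compounds are considered here, and "the series" means these few. Any claim that something is new, unique, unknown or untested is made for them only; others in the source may bear on it.

Measured compounds:
- compound 1, `COc1cc2c(Oc3ccc(NC(=O)c4cc(-c5ccccc5)ccn4)cc3F)ccnc2cc1OCCCN1CCCC1`, 1580 nM in a functional assay on A549 cells (Homo sapiens) for cytotoxicity, read by MTT assay, with a stated time of 72 h; a higher number here means a weaker inhibitor, a lower number a stronger inhibitor
- compound 2, `COc1cc2c(Oc3ccc(NC(=O)c4cc(-c5ccc(F)cc5)ccn4)cc3F)ccnc2cc1OCCCN1CCCC1`, 1800 nM in this assay

Compound 1 and compound 2 share one core. The difference between them is fluoro in place of hydrogen on an aromatic carbon, and the step it made in this assay is a 1.1-fold higher number from compound 1 to compound 2 (0.06 log units; within the scatter). The two values therefore give no ground for any ordering of compound 1 against compound 2.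

Compound 3, `COc1cc2c(Oc3ccc(NC(=O)c4nccc(-c5ccc(F)cc5)n4)cc3F)ccnc2cc1OCCCN1CCCCC1`, has a different core; how it differs from the core of compound 1 is not broken down here. For compound 3 the entry in this assay reads "not determined" (no result reported), so no result is reported for it.

Compound 4, `COc1cc2c(Oc3ccc(NC(=O)c4nccc(-c5ccc(F)cc5F)n4)cc3F)ccnc2cc1OCCCN1CCCCC1`, is not yet measured. It differs from compound 3 by fluoro in place of hydrogen on an aromatic carbon. This is the same kind of change as that from compound 1 to compound 2, but not the same: in compound 2 the entering fluoro sits para to a large group, whereas in compound 4 it sits ortho to a large group and meta to a fluoro group.

Among the compounds with values here, only one paired measurement of this kind of change exists, and it lies within the scatter. With no number for compound 3, the expectation for compound 4 rests on compound 1 at 1580 nM and compound 2 at 1800 nM as the nearest measured neighbours, and on the small step seen between them. Compound 4 is accordingly expected to give about 1800 nM in this assay, with a wide range from 600 nM to 6000 nM, since the change of core is unquantified.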

Compound 4, half-maximal inhibitory concentration: 470 nM
Estimate against measurement, compound 4: 3.8-fold (0.58 log units) above; the whole stated range lies above it.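

In this assay compound 4 gives 470 nM but the entry for compound 3 carries no number, so the step from compound 3 to compound 4 cannot be read. No supporting data bear on this value. The compounds shown leave open what 4-fluorophenyl to 2,4-difluorophenyl does to the number in this core, and how the core of compound 4 compares with the core of compound 1.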